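From a Bromophenyl to a Chloromethoxyphenyl Ring

The source may hold more compounds than are shown below. What is called first, only, known or untested is meant among the compounds shown, and "the series" means these compounds.

Measured compounds in a functional assay on KBVIN cells (Homo sapiens) for antiproliferative activity, read by sulforhodamine B assay, with a stated time of 3 days; a higher number here means that more compound is needed for the effect, a lower number that less compound is needed:
compound 1 `CCC1=C(O)c2c(oc(-c3ccc(C)cc3)cc2=O)C(CC)(CC)C1=O`: 0.08 uM
compound 2 `CCC1=C(O)c2c(oc(-c3ccc(Br)cc3)cc2=O)C(CC)(CC)C1=O`: 15.7 uM
compound 3 `CCC1=C(O)c2c(oc(-c3ccccc3C(F)(F)F)cc2=O)C(CC)(CC)C1=O`: 43.1 uM

Compound 2 holds the second highest of the three numbers in this assay. Within the data shown here, compound 3 gives 43.1 uM and so stands nearest to it, while compound 1 with 0.08 uM lies furthest away; the step of a 200-fold higher number from compound 1 to compound 2 (2.29 log units; beyond the scatter) is the only measured step in this set, and it shows that a single change on the pendant aryl ring can move the number a long way.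

Compound 4 `CCC1=C(O)c2c(oc(-c3ccc(OC)c(Cl)c3)cc2=O)C(CC)(CC)C1=O` has not been measured. It differs from compound 2 by 3-chloro-4-methoxyphenyl in place of 4-bromophenyl on an aromatic carbon. No measured step covers this exact exchange, so the expectation rests on the one step shown: a change at the same ring carried a large effect there, and the direction here is uncertain. Given that compound 1, bearing a methyl on that ring, gives 0.08 uM, a somewhat lower number than compound 2 is expected, estimated as a 3.9-fold lower number from compound 2 to compound 4 (0.59 log units; beyond the scatter). Compound 4 is therefore estimated at 4 uM, with a range from 0.4 uM to 40 uM.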

Compound 4, concentration for half-maximal effect: 1.37 uM
Compound 4: the middle estimate sits 2.9-fold (0.47 log units) above what was measured; measured number inside the range.
By their numbers in this assay, from the lowest: compound 1; then compound 4; then compound 2; then compound 3.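

The exchange of 4-bromophenyl for 3-chloro-4-methoxyphenyl gives an 11-fold lower number from compound 2 to compound 4 (1.06 log units; beyond the scatter) in this assay, so a halogen on the pendant ring does not by itself hold the number at the level of compound 2. Among these compounds, the exchange of 4-methylphenyl for the same ring gives a 17-fold higher number from compound 1 to compound 4 (1.23 log units; beyond the scatter), which leaves the methyl-bearing ring of compound 1 with the lowest number so far, and the position thus separates these three rings by large steps. Nothing available explains either step.

The compounds shown leave open whether the chloro or the methoxy group accounts for the step, since the two enter together. They also leave open how a ring carrying an amine or a longer alkyl chain in place of the methyl of compound 1 would stand in this assay.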